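Swapping ethyl for oxetan-3-yl on a ring amine

The compounds below may be only part of what the source reports. "The series", "measured", "known", "first", "only" and "open" are said of these compounds alone.

Compound 1 `Cc1cc(NC(=O)[C@H]2CN(C)C[C@@H]2c2ccc(/C=C/C(=O)Nc3ccccc3N)cc2)ccc1F` gives 15 mL/min/kg
Compound 2 `CC(C)NC(=O)[C@H]1CN(C)C[C@@H]1c1ccc(/C=C/C(=O)Nc2ccccc2N)cc1` gives 8 mL/min/kg
Compound 3 `CCN1C[C@H](C(=O)Nc2ccc(Cl)cc2)[C@@H](c2ccc(/C=C/C(=O)Nc3ccccc3N)cc2)C1` gives 12 mL/min/kg

In an in vitro ADME assay on microsomes from liver (Homo sapiens) for pharmacokinetics, read by LC-MS, with a stated time of 10 min, tested at 1 uM (on this read-out lower numbers stand for slow clearance and higher numbers for fast clearance), compound 3 gives 12 mL/min/kg and so lies within the usual scatter of both other compounds. The change to compound 4 `Nc1ccccc1NC(=O)/C=C/c1ccc([C@H]2CN(C3COC3)C[C@@H]2C(=O)Nc2ccc(Cl)cc2)cc1` is oxetan-3-yl in place of ethyl on an amine nitrogen in a ring. Among the compounds with values here, the only measured step is a 1.9-fold lower number from compound 1 to compound 2 (0.27 log units; within the scatter) on an amide-type nitrogen, not on this amine. No measurement isolates a change at the ring amine. The step expected in this assay is therefore none beyond the scatter, estimated as (a 1.2-fold lower number from compound 3 to compound 4 (0.08 log units; within the scatter)). Compound 4 is expected to give 10 mL/min/kg within an estimated range of 5 mL/min/kg to 20 mL/min/kg on repeat measurements.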

Compound 4, clearance: 13 mL/min/kg
Compound 4: the middle estimate sits 1.3-fold (0.11 log units) below what was measured; low and high end bracket the measured number.
By their numbers in this assay, from the lowest: compounds 2, 3, 4 and 1 (each within the scatter of the next).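

On the amine nitrogen in the ring, oxetan-3-yl replaces ethyl and adds a four-membered ring with one oxygen, yet in this assay the two compounds lie within the scatter (a 1.1-fold higher number from compound 3 to compound 4 (0.03 log units; within the scatter)). Within the data shown here, this is the first measured change at this position, so the ring amine can carry either group without a step beyond the scatter, at least with the (4-chlorophenyl)carbamoyl group in place. No measured evidence here explains this result.

From the compounds shown here alone, whether an acetyl group or a longer chain such as n-butyl on this nitrogen would also stay within the scatter remains open. So does whether the same swap would behave alike with the isopropyl amide of compound 2.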